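Cyano in place of butoxy on the shared core

This account rests on a few compounds, and the source may have more. Where it says the series, first, only, none or still open, it means among the compounds named here.

Measured in a toxicity assay on MDCK cells (Canis lupus familiaris) for cytotoxicity, read by CCK-8 assay, with a stated time of 48 h (a lower number here means that less compound is tolerated, a higher number that more compound is tolerated), each value being a limit of the assay and not a number:
compound 1 (`CCCCOc1ccc(C(=O)NNc2c(Br)cccc2Br)cc1`): > 100000 nM
compound 2 (`COc1cccc(C(=O)NNc2c(Br)cccc2Br)c1`): > 100000 nM
compound 3 (`COc1ccccc1C(=O)NNc1c(Br)cccc1Br`): > 100000 nM

Compound 1 has no exact number in this assay and is known only through the limit (> 100000 nM). The whole measured set stands in the same place: the limit of > 100000 nM in this assay, at which 3 of the 3 values shown sit. Among the measured compounds shown here, no pair of measured compounds therefore gives a step of known size, and nothing measured so far shows how far a change of group can move the value.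

The next compound, compound 4 (`N#Cc1ccc(C(=O)NNc2c(Br)cccc2Br)cc1`), keeps the core of compound 1 and changes one group. The change lies para to a large group (cyano in place of butoxy on an aromatic carbon).

In this assay no step beyond the scatter is expected for this change, and no direction is predicted. That expectation rests on compound 1, whose > 100000 nM is a limit. The expected change is a number no higher from compound 1 to compound 4 (the limit leaves the size open) in the estimate made here. A report of only a limit is expected to be the likeliest outcome. For compound 4 the estimated half-maximal cytotoxic concentration is 100000 nM (expected range 50000 nM to 200000 nM).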

Compound 4, half-maximal cytotoxic concentration: > 100000 nM
Compound 4 gave a limit, no number (the forecaster's own chance of this, stated with the estimate: 85%); the middle value lies on the limit itself.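

Among the compounds shown here, compound 1 and compound 4 are both known in this assay only through limits, and no step between them can be read for cyano in place of butoxy. The compounds shown leave open what exact value any of them has and how far a change of group can move it, with the whole set in one place: the limit of > 100000 nM in this assay, at which 4 of the 4 values shown sit.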